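The source may report more compounds than this note shows. Statements on the series, on what has been measured and on what is new or still open speak of the compounds shown alone.

Compound 1 `COc1ncc(-c2ccc3ncnc(Nc4ccc(OCCO)cc4)c3c2)cc1NS(C)(=O)=O` gives 5200 nM in a functional assay on A549 cells (Homo sapiens) for antiproliferative activity, read by sulforhodamine B assay, with a stated time of 72 h; on this read-out higher numbers stand for weaker inhibition and lower numbers for stronger inhibition; compound 2 `COc1ncc(-c2ccc3ncnc(Nc4cnn(CCCO)c4)c3c2)cc1NS(C)(=O)=O` gives 3600 nM; compound 3 `COC(=O)Cn1cc(Nc2ncnc3ccc(-c4cnc(OC)c(NS(=O)(=O)c5ccc(F)cc5F)c4)cc23)cn1` gives 4280 nM.

Compound 2 carries the lowest of these three numbers, but its gaps to compound 3 and to compound 1 both lie within the scatter, so the three compounds cannot be ordered. For the measured compounds named here, the only single-point step on record, a 1.4-fold lower number from compound 1 to compound 2 (0.16 log units; within the scatter), concerns the group on the ring nitrogen and does not bear on the present change. Compound 4 `COC(=O)CCn1cc(Nc2ncnc3ccc(-c4cnc(OC)c(NS(C)(=O)=O)c4)cc23)cn1` differs from compound 2 by methoxycarbonyl in place of hydroxymethyl on a saturated chain carbon, two bonds along the chain from an aromatic nitrogen. Compound 3 already carries a (methoxycarbonyl)methyl chain on the same ring and sits within the scatter of compound 2, though its sulfonamide differs. Compound 4 is therefore expected to show a 1.1-fold higher number from compound 2 to compound 4 (0.02 log units; within the scatter), no step beyond the scatter, and its estimated value is 3800 nM, from 1500 nM to 9500 nM.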

Compound 4, half-maximal inhibitory concentration: 2990 nM
The estimate for compound 4 lay 1.3-fold (0.10 log units) above the measured number; low and high end bracket the measured number.
By their numbers in this assay, from the lowest: compounds 4, 2, 3 and 1 (each within the scatter of the next).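

In this assay, for the compounds shown here, exchanging hydroxymethyl, with its hydrogen-bond donor, for methoxycarbonyl, with none, gives a 1.2-fold lower number from compound 2 to compound 4 (0.08 log units; within the scatter) at this chain position, the first comparison of this change with the sulfonamide held constant. Replacing 4-(2-hydroxyethoxy)phenyl with 1-(2-(methoxycarbonyl)ethyl)-1H-pyrazol-4-yl likewise gives a 1.7-fold lower number from compound 1 to compound 4 (0.24 log units; within the scatter), so neither step separates the compounds. No measurement here offers an explanation for these results. The compounds shown leave open whether a carboxylic acid or an amine at the end of this chain, or a longer chain, would give a step beyond the scatter.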